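Swapping dimethylamino for tert-butyl on compound 2

The source may report more compounds than this note shows. Statements on the series, on what has been measured and on what is new or still open speak of the compounds shown alone.

In a functional assay on B16-F0 cells (Mus musculus) for inhibition, read by CCK-8 assay, with a stated time of 48 h (a lower number here means a stronger inhibitor, a higher number a weaker inhibitor), compound 2 `COc1cc(-c2ccnc3cc(-c4ccc(N(C)C)cc4)nn23)cc(OC)c1OC` gives 702 nM. That is the only number shown; the other result is a limit. Compound 1 `COc1cc(-c2cc3nccc(-c4cc(OC)c(OC)c(OC)c4)n3n2)cc(OC)c1OC` is reported in this assay only as a limit, > 10000 nM, as noted in the limit of > 10000 nM in this assay, at which 1 of the 2 values shown sits. Compound 3 `COc1cc(-c2ccnc3cc(-c4ccc(C(C)(C)C)cc4)nn23)cc(OC)c1OC` differs from compound 2 by tert-butyl in place of dimethylamino on an aromatic carbon. Going by the values given here, no step between two measured compounds is available, so the size of this change is uncertain; a modest loss or a result within the usual scatter is expected, as a 1.7-fold higher number from compound 2 to compound 3 (0.23 log units; within the scatter). Compound 3 is therefore estimated at 1200 nM in this assay, expected between 300 nM and 5000 nM.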

Compound 3, half-maximal inhibitory concentration: > 10000 nM
Compound 3 gave a limit, no number; the forecaster's own chance of this, stated with the estimate: 15%; middle value at least 8.3-fold (0.92 log units) away from the limit.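

The earlier compounds shown here offered no step at this position. Here, in this assay, tert-butyl in place of dimethylamino on this aromatic carbon gives an at least 14-fold higher number from compound 2 to compound 3 (1.15 log units; beyond the scatter), so 4-(dimethylamino)phenyl cannot be exchanged for 4-(tert-butyl)phenyl without a large loss. Compound 3 is reported only as a limit, so the full size of the step stays unfixed, and that limit is shared: the limit of > 10000 nM in this assay, at which 2 of the 3 values shown sit.

The compounds shown cannot separate losing the nitrogen from gaining the extra carbon. On these data alone, whether a methylamino group, a morpholine or a methoxy group would keep the activity remains open.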